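Adding a methyl to compound 3

A few compounds are considered here, and "the series" means these few. Any claim that something is new, unique, unknown or untested is made for them only; others in the source may bear on it.

Measured in a functional assay on RKO cells (Homo sapiens) for cytotoxicity, read by resazurin assay, with a stated time of 72 h; a higher number here means a weaker inhibitor, a lower number a stronger inhibitor:
Compound 1 `Cc1nccn1-c1csc(Nc2cccc(Br)c2)n1`: > 100000 nM (a limit)
Compound 2 `Cc1nccn1-c1csc(Nc2ccc(S(N)(=O)=O)cc2)n1`: 49000 nM
Compound 3 `c1ccc(Nc2nc(-n3ccnc3)cs2)cc1`: > 100000 nM (a limit)

Compound 3 stands at the limit of > 100000 nM in this assay, at which 2 of the 3 values shown sit, so it has no number. Compound 4 `Cc1nccn1-c1csc(Nc2ccccc2)n1` differs from it by methyl in place of hydrogen on an aromatic carbon: 1H-imidazol-1-yl becomes 2-methyl-1H-imidazol-1-yl. Going by the values given here, no measured pair isolates this change. Compound 1, which carries the same 2-methyl-1H-imidazol-1-yl group, is also a limit at > 100000 nM. Compound 2, with that group too, gives 49000 nM. The step expected an at least 1.1-fold lower number from compound 3 to compound 4 (0.04 log units; that floor lies within the scatter) is none beyond the scatter in this assay. The estimate for compound 4 is 90000 nM, expected within 40000 nM to 200000 nM.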

Compound 4, half-maximal inhibitory concentration: 32500 nM
Compound 4: the middle estimate sits 2.8-fold (0.44 log units) above what was measured; the whole stated range lies above it.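

In this assay, going by these compounds alone, 2-methyl-1H-imidazol-1-yl in place of 1H-imidazol-1-yl gives an at least 3.0-fold lower number from compound 3 to compound 4 (0.48 log units; beyond the scatter), the first direct reading of a methyl on this aromatic carbon between two ring nitrogen atoms. With that methyl kept, hydrogen in place of bromo gives an at least 3.0-fold lower number from compound 1 to compound 4 (0.48 log units; beyond the scatter), whereas hydrogen in place of sulfamoyl gives a 1.5-fold lower number from compound 2 to compound 4 (0.18 log units; within the scatter). Compound 3 and compound 1 are limits, so their steps are bounds only: the limit of > 100000 nM in this assay, at which 2 of the 4 values shown sit.

As far as these compounds go, the true size of the methyl step stays open. So does what an ethyl group or an amine on this same carbon would give.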